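This account rests on a few compounds, and the source may have more. Where it says the series, first, only, none or still open, it means among the compounds named here.

Working notes on the series. The reference point is compound 1 `O=C(COc1ccc(C(=O)/C=C/c2ccc(F)c(F)c2)cc1)N[C@H]1CCOC1=O`. In a functional assay on MGC-803 cells (Homo sapiens) for antiproliferative activity, read by MTT assay, with a stated time of 72 h (a higher number here means a weaker inhibitor, a lower number a stronger inhibitor), compound 1 returns only a limit, > 64000 nM, so no number is known for it; the limit is the limit of > 64000 nM in this assay, at which 1 of the 3 values shown sits, and compound 1 sits at it. Two further members of the set give numbers: compound 2 `O=C1OCC[C@@H]1NC(=S)SCCOc1ccccc1` gives 53800 nM in this assay, and compound 3 `O=C1OCC[C@@H]1NC(=S)SCCOc1ccccc1[N+](=O)[O-]` gives 47000 nM. Among the compounds with values here, the one measured step, a 1.1-fold lower number from compound 2 to compound 3 (0.06 log units; within the scatter), is the only guide to what a nitro group does here, and it is within the scatter.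

The unmeasured compound 4 `O=C(COc1ccc(C(=O)/C=C/c2cccc([N+](=O)[O-])c2)cc1)N[C@H]1CCOC1=O` differs from compound 1 by 3-nitrophenyl in place of 3,4-difluorophenyl on a double-bonded chain carbon bound to a double-bonded chain carbon. The step of compound 2 to compound 3 bears on this only loosely: it exchanges hydrogen for nitro on a different part of a different core, and it was within the scatter. Within the data shown here, no measured step matches the loss of the two fluorines. With compound 1 itself at the limit, no move beyond the scatter is expected in this assay; the expected step is a number no higher from compound 1 to compound 4 (the limit leaves the size open). Compound 4 is therefore estimated at 64000 nM in this assay, with a range from 30000 nM to 150000 nM, and a limit rather than a number is the likelier outcome.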

Compound 4, half-maximal inhibitory concentration: > 64000 nM
Compound 4: no number, only a limit; the forecaster's own chance of this, stated with the estimate: 60%; the middle value sits exactly at the limit.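

Compound 1 and compound 4 both return only a limit in this assay, so no step between them can be read: the limit of > 64000 nM in this assay, at which 2 of the 4 values shown sit.

The compounds shown leave open how 3-nitrophenyl and 3,4-difluorophenyl compare on the shared core in this assay.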